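Aryl for Cyclohexyl at the Ortho Position

The source may hold more compounds than are shown below. What is called first, only, known or untested is meant among the compounds shown, and "the series" means these compounds.

Measured so far:
compound 1, `CCCCN(C)c1cc(C(F)(F)F)ccc1CNC(=O)C(C)c1ccc(NS(C)(=O)=O)c(F)c1`, 1.2 nM
compound 2, `CC(C(=O)NCc1ccc(C(F)(F)F)cc1C1CCCCC1)c1ccc(NS(C)(=O)=O)c(F)c1`, 0.6 nM

In an assay on CHO cells for antagonist activity at transient receptor potential cation channel subfamily V member 1 (Homo sapiens), read by FLIPR (on this read-out higher numbers stand for weaker inhibition and lower numbers for stronger inhibition), compound 2 gives the lower of the two numbers, but its distance from compound 1 is a 2.0-fold lower number from compound 1 to compound 2 (0.30 log units; within the scatter), so the two cannot be ordered on this read-out. Compound 3, `COc1cc(OC)cc(-c2cc(C(F)(F)F)ccc2CNC(=O)C(C)c2ccc(NS(C)(=O)=O)c(F)c2)c1`, is not yet measured. It differs from compound 2 by 3,5-dimethoxyphenyl in place of cyclohexyl on an aromatic carbon. Within the data shown here, only one measured step exists, and it touches the same position: the change from butyl(methyl)amino to cyclohexyl, a 2.0-fold lower number from compound 1 to compound 2 (0.30 log units; within the scatter), left the number essentially where it was. Nothing measured shows how an aromatic group with two methoxy substituents behaves at this position, so the expectation rests on that one step and carries wide uncertainty. The step from compound 2 to compound 3 is expected to be a 2.0-fold higher number from compound 2 to compound 3 (0.30 log units; within the scatter), not clearly beyond the scatter. Compound 3 is therefore estimated at 1.2 nM, with a range from 0.3 nM to 5 nM.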

Compound 3, inhibition constant: 5.8 nM
Compound 3: the middle estimate sits 4.8-fold (0.68 log units) below what was measured; the measured number lies above the stated range.
By their numbers in this assay, from the lowest: compounds 2 and 1 (each within the scatter of the next); then compound 3.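

In this assay this position no longer looks indifferent to what it carries: 3,5-dimethoxyphenyl gives a 9.7-fold higher number from compound 2 to compound 3 (0.99 log units; beyond the scatter) and, set against butyl(methyl)amino, a 4.8-fold higher number from compound 1 to compound 3 (0.68 log units; beyond the scatter) in the same direction, whereas the two earlier groups could not be ordered. The change brings in an aromatic ring, a larger group and hydrogen-bond acceptors all at once, so this single step cannot assign the weaker inhibition to any one of them. Nothing available explains the rise in the number.

The compounds shown leave open whether the aromatic ring itself or its two methoxy substituents carry the loss, a question that an unsubstituted phenyl or a 3,5-dimethylphenyl group would address. They also do not show whether a smaller ring such as cyclopropyl would fit this pattern.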